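Halogen swap on the sulfonyl aryl, compound 3 to 4

The compounds below may be only part of what the source reports. "The series", "measured", "known", "first", "only" and "open" are said of these compounds alone.

Values in a functional assay on HL-60 cells (Homo sapiens) for inhibition, read by CCK-8 assay, with a stated time of 48 h, tested at 20 uM (on this read-out higher numbers stand for more inhibition of growth at the one concentration tested and lower numbers for less inhibition of growth), are as follows
- compound 1 `COc1ccc(Cc2nnc(NC(=O)/C(C#N)=C/c3ccccc3OS(=O)(=O)c3ccc(F)cc3)s2)cc1` gives 25%
- compound 2 `COc1ccc(S(=O)(=O)Oc2ccccc2/C=C(\C#N)C(=O)Nc2nnc(Cc3ccc(Cl)cc3)s2)cc1` gives 99%
- compound 3 `N#C/C(=C\c1ccccc1OS(=O)(=O)c1ccc(Cl)cc1)C(=O)Nc1nnc(Cc2ccc(Cl)cc2)s1` gives 15%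

Compound 3 sits at the low end of the set, within the scatter of compound 1 and far under compound 2. Compound 4 `N#C/C(=C\c1ccccc1OS(=O)(=O)c1ccc(F)cc1)C(=O)Nc1nnc(Cc2ccc(Cl)cc2)s1` has fluoro in place of chloro on an aromatic carbon and keeps everything else. Among the measured compounds shown here, the one measured step on this carbon, a number 84 percentage points lower from compound 2 to compound 3 (beyond the scatter) (chloro in place of methoxy), was large, but it is not a swap of one halogen for another. Compound 1 carries the same (4-fluorophenyl)sulfonyl group at 25% but differs elsewhere. No step beyond the scatter is therefore expected, and the estimate means a number 7 percentage points higher from compound 3 to compound 4 (within the scatter) in this assay. For compound 4 the estimated value is 22% (expected range 6% to 55%).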

Compound 4, percent growth inhibition at one concentration: 20%
Estimate against measurement, compound 4: 2 percentage points above; low and high end bracket the measured number.
By their numbers in this assay, from the lowest: compounds 3, 4 and 1 (each within the scatter of the next); then compound 2.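

In this assay, fluoro and chloro on this carbon read alike, with a number 5 percentage points higher from compound 3 to compound 4 (within the scatter), while methoxy there stands apart, with a number 79 percentage points lower from compound 2 to compound 4 (beyond the scatter). On the other side of the molecule, the change between the same two groups gives a number 5 percentage points lower from compound 1 to compound 4 (within the scatter). Chloro in place of methoxy therefore does not carry over from one core to the other: the same change on two cores in this assay, a number 84 percentage points lower (beyond the scatter) from compound 2 to compound 3 and a number 5 percentage points lower (within the scatter) from compound 1 to compound 4, 79 percentage points apart, beyond the scatter of two such steps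

Open, on these data alone, is whether the high number is unique to methoxy on the sulfonyl aryl, or also appears with ethoxy, dimethylamino or hydroxyl on this carbon. Also open, as far as these compounds go, is what methoxy on both aromatic rings at once would give.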